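This account rests on a few compounds, and the source may have more. Where it says the series, first, only, none or still open, it means among the compounds named here.

The measured compounds in a functional assay on PC-3 cells (Homo sapiens) for cytotoxicity, read by sulforhodamine B assay; a lower number here means a stronger inhibitor, a higher number a weaker inhibitor:

Compound 1, `[N-]=[N+]=N[C@@H]1C(n2ccc(=O)[nH]c2=O)[Se][C@H](CO)[C@H]1O`: compound 1 gives > 100000 nM, which is a limit of this assay and not a number.
Compound 2, `[N-]=[N+]=N[C@@H]1C(n2cc(F)c(=O)[nH]c2=O)[Se][C@H](CO)[C@H]1O`: compound 2 gives > 100000 nM, again a limit of this assay rather than a number.

Within the data shown here, compound 2 therefore stands only at a limit, and the one other value shown sits at the same limit (the limit of > 100000 nM in this assay, at which 2 of the 2 values shown sit). Among the measured compounds shown here, the single measured step, a step that the two limits leave unreadable from compound 1 to compound 2, is consequently unreadable in size and direction; both of its ends are limits.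

Compound 3, `[N-]=[N+]=N[C@@H]1C(n2cc(Br)c(=O)[nH]c2=O)[Se][C@H](CO)[C@H]1O`, has not yet been measured in this assay. It differs from compound 2 by bromo in place of fluoro on an aromatic carbon. For the measured compounds named here, only the step from compound 1 to compound 2 bears on this change, since it touches the same aromatic carbon, and that step is unreadable, so no size of step can be taken from it. With both measured values sitting at the limit, the expectation for compound 3 is simply that it will again most likely be reported as a limit in this assay.

Compound 3 is thus estimated at 100000 nM, within a range from 30000 nM to 300000 nM. This estimate means a step of a number no higher from compound 2 to compound 3 (the limit leaves the size open), which is an expectation rather than a measurement.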

Compound 3, half-maximal inhibitory concentration: > 100000 nM
Compound 3 was reported as a limit; the forecaster's own chance of this, stated with the estimate: 75%; the middle value lies on the limit itself.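

Compound 3 also gives only a limit in this assay, so the steps among compound 1, compound 2 and compound 3 cannot be read in size or direction: the limit of > 100000 nM in this assay, at which 3 of the 3 values shown sit.

The compounds shown leave open how strongly any of them acts on these cells, and whether hydrogen, fluoro or bromo on this aromatic carbon makes any difference.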